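A small ring swap on a sulfonamide

The source may report more compounds than this note shows. Statements on the series, on what has been measured and on what is new or still open speak of the compounds shown alone.

Three compounds measured in a functional assay on HeLa cells (Homo sapiens) for antiproliferative activity, read by sulforhodamine B assay, with a stated time of 72 h (on this read-out lower numbers stand for stronger inhibition and higher numbers for weaker inhibition), give these values
Compound 1 `O=C1CS/C(=N/Nc2nncc3ccccc23)N1c1ccccc1` gives 56 nM
Compound 2 `O=S(=O)(Nc1ncccn1)c1ccc(Nc2nncc3ccccc23)cc1` gives 14 nM
Compound 3 `Clc1ccc(C(/C=C/c2ccccc2)=N\Nc2nncc3ccccc23)cc1` gives 3.3 nM

Compound 2 (14 nM) sits in the middle of these three numbers. Compound 1 reads higher (56 nM) and compound 3 reads lower (3.3 nM), and both gaps lie beyond the usual scatter of repeated measurements.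

The next compound to be tested is compound 4 `O=S(=O)(Nc1ccccn1)c1ccc(Nc2nncc3ccccc23)cc1`, which has pyridin-2-yl in place of pyrimidin-2-yl on a sulfonamide nitrogen. Everything else matches compound 2. Both groups are six-membered aromatic rings, so the change is a modest one on paper.

The three measured compounds differ from one another in more than one place, so none of them shows directly what this swap does. The best guide is therefore compound 2 itself (14 nM), and the wide spread across the three compounds argues for a generous range. In this assay the estimated step of a 1.1-fold higher number from compound 2 to compound 4 (0.03 log units; within the scatter) is expected to stay within the scatter, with no clear direction. The value expected for compound 4 is 15 nM (estimated range from 5 nM to 45 nM).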

Compound 4, half-maximal inhibitory concentration: 26 nM
Compound 4: middle estimate off by 1.7-fold (0.24 log units), on the low side, within the range that was stated.
By their numbers in this assay, from the lowest: compound 3; then compounds 2 and 4 (each within the scatter of the next); then compound 1.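

In this assay, among these compounds, the exchange of pyrimidin-2-yl for pyridin-2-yl on a sulfonamide nitrogen gives a 1.9-fold higher number from compound 2 to compound 4 (0.27 log units; within the scatter), the first direct reading of a single change, and it leaves the two compounds indistinguishable. The pyridin-2-yl ring has fewer ring nitrogens and fewer hydrogen-bond acceptors than the pyrimidin-2-yl ring, yet at this position that difference does not produce a step beyond the usual scatter, so this particular exchange is tolerated in this assay. No measurement of any property of these two groups accompanies the result, so the data offer no explanation for it.

As far as these compounds go, it remains open whether a ring with no nitrogen at all, such as plain phenyl, or a five-membered ring, such as thiazol-2-yl, would also stay within the scatter of compound 2 on the same sulfonamide nitrogen. From the compounds shown here alone, it is also open whether this nitrogen needs a ring at all, as a simple methyl group or a lone hydrogen in that place would show in this assay.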